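Intrinsic activity in a spiro-piperidine amide series

The source may hold more compounds than are shown below. What is called first, only, known or untested is meant among the compounds shown, and "the series" means these compounds.

Measured so far:
compound 1, `CC(C)(C)OC(=O)N1CCC2(CCN(C(=O)Nc3ccc(S(C)(=O)=O)cc3Br)CC2)CC1`: 165%
compound 2, `CC(C)(C)OC(=O)N1CCC2(CC1)CC(C(=O)Nc1cc(F)c(C#N)cc1F)=NO2`: 170%

Both values come from an in vitro functional assay on cells with Glucose-dependent insulinotropic receptor (Homo sapiens) as the target, read by AlphaScreen and cAMP accumulation, with a stated time of 45 min; a lower number here means a smaller maximal response, a higher number a larger maximal response. In this assay compound 1 gives 165% and compound 2 gives 170%. The two numbers lie within the usual scatter of each other, so nothing separates compound 1 from compound 2 on this read-out; both sit well above the reference agonist's maximal response.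

Compound 3, `N#Cc1cc(F)c(NC(=O)C2=NOC3(CCN(c4nc(-c5ccccc5)no4)CC3)C2)cc1F`, is not yet measured. It keeps the amide and the aromatic ring of compound 2 and differs only in the group on the amine nitrogen in a ring:

3-phenyl-1,2,4-oxadiazol-5-yl in place of tert-butoxycarbonyl on an amine nitrogen in a ring

Within the data shown here, no step between two measured compounds is recorded for a change of this kind, so the size of its effect in this assay is open. With only two measured points, both high and within scatter of each other, the expectation for compound 3 is a step of a number 20 percentage points lower from compound 2 to compound 3 (beyond the scatter), small or not beyond the scatter, in either direction, with a downward lean allowed for by a wide range. Compound 3 is therefore estimated at 150%, with a range from 90% to 190%.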

Compound 3, intrinsic activity: the largest response reached, in percent of the reference agonist's: 173%
Beside the measured number, compound 3's estimate is 23 percentage points below it; the measured number falls inside the stated range.
By their numbers in this assay, from the lowest: compounds 1, 2 and 3 (each within the scatter of the next).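

In this assay, among these compounds, the amine nitrogen in a ring of the spiro-joined six-membered ring accepts 3-phenyl-1,2,4-oxadiazol-5-yl in place of tert-butoxycarbonyl with a number 3 percentage points higher from compound 2 to compound 3 (within the scatter), so this pair gives the first direct reading at this position and the read-out does not separate the two groups. The maximal response in this pair therefore does not rest on tert-butoxycarbonyl itself: the double bond outside aromatic rings leaves with that group, two aromatic rings enter, and the response stays within the scatter. No accompanying data bear on why the two groups read alike.

The compounds shown leave open how far this tolerance extends on the same nitrogen, for example to the free amine carrying only a hydrogen, a small acetyl group, or a benzyl group, any of which would show whether a substituent of this bulk is needed at all. They also leave open whether the 1,2,4-oxadiazole or the phenyl ring carries the response, which a 3-methyl-1,2,4-oxadiazol-5-yl group on that nitrogen would begin to separate.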